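This account rests on a few compounds, and the source may have more. Where it says the series, first, only, none or still open, it means among the compounds named here.

Measured so far in a physicochemical assay for lipophilicity, at pH 7.4; on this read-out lower numbers stand for lower lipophilicity and higher numbers for higher lipophilicity:
Compound 1 `Cc1nc(C)c(-c2nnc(-c3ccc(OC(C)C)c(Cl)c3)s2)s1` gives 7.76
Compound 2 `CC(C)Oc1ccc(-c2nnc(-n3ncc4c3CCN(CCC(=O)O)C4)s2)cc1Cl` gives 3.54
Compound 3 `Cc1nn(-c2nnc(-c3ccc(OC(C)C)c(Cl)c3)s2)c(C)c1CC(=O)O` gives 3.62

Compound 1 stands highest of the three numbers in this assay. Its nearest companion is compound 3, whose value lies far lower, beyond the usual scatter; the furthest is compound 2, lower still, also beyond the scatter. Compounds 2 and 3 themselves sit so close together that nothing can be said about which is the higher. No pair among these three differs in only one place, so no single measured step is available to guide a prediction.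

Compound 4 `CC(C)Oc1ccc(-c2nnc(-c3ccno3)s2)cc1Cl` has not yet been measured in this assay. It differs from compound 1 at one place on an aromatic carbon of the shared core: 1,2-oxazol-5-yl in place of 2,4-dimethyl-1,3-thiazol-5-yl on an aromatic carbon. The group that leaves carries more heavy atoms than the one that enters, and sulfur gives way to oxygen, so a drop in the read-out is expected for compound 4 rather than a rise or no change. The step from compound 1 to compound 4 is estimated at a number 1.66 log units lower from compound 1 to compound 4 (beyond the scatter). Compound 4 is therefore expected to come in around 6.1, with a likely range from 4.8 to 7.4.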

Compound 4, distribution coefficient: 6.93
Compound 4: middle estimate off by 0.83 log units, on the low side; the measured number falls inside the stated range.
By their numbers in this assay, from the lowest: compounds 2 and 3 (each within the scatter of the next); then compound 4; then compound 1.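

In this assay, for the compounds shown here, 1,2-oxazol-5-yl in place of 2,4-dimethyl-1,3-thiazol-5-yl on this aromatic carbon of the shared core gives a number 0.83 log units lower from compound 1 to compound 4 (beyond the scatter), the first change in the set that can be read at a single place. Both groups are uncharged five-membered aromatic rings with 2 hetero atoms, and both carry 0 hydrogen-bond donors and 2 hydrogen-bond acceptors, so the read-out at this position moves even with those counts held constant. What does change is the size and make-up of the group, from 7 heavy atoms to 5, with sulfur giving way to oxygen, but no separate measurement bears on why the number moved.

This single step cannot divide the change between the loss of the methyl groups and the exchange of sulfur for oxygen, and a plain 1,3-thiazol-5-yl group, without the methyl groups, would help to pull those two apart. Going by these compounds, it also remains open how far the read-out would move with a different kind of group on this carbon, such as an amine.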